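A few compounds are considered here, and "the series" means these few. Any claim that something is new, unique, unknown or untested is made for them only; others in the source may bear on it.

Working notes on the series.

The shared core of compound 1 `CC(C)Nc1ccc(NC(=O)c2cc(Cl)ccc2O)c(Cl)c1` carries an isopropyl on a nitrogen on an aromatic ring. In an ADME assay on A549 cells (Homo sapiens) for cytotoxicity, read by resazurin assay, with a stated time of 48 h (a higher number here means that more compound is tolerated, a lower number that less compound is tolerated), compound 1 gives 11000 nM, the lowest of the three numbers in hand. Compound 2 `COc1ccc(CNc2ccc(NC(=O)c3cc(Cl)ccc3O)c(Cl)c2)cc1` gives 80700 nM and compound 3 `O=C(Nc1ccc(NCc2ccc(O)cc2)cc1Cl)c1cc(Cl)ccc1O` gives 116000 nM. Both replacements of the isopropyl raised the number: a 7.3-fold higher number from compound 1 to compound 2 (0.87 log units; beyond the scatter) and an 11-fold higher number from compound 1 to compound 3 (1.02 log units; beyond the scatter). Between the two aromatic replacements the difference is small, a 1.4-fold higher number from compound 2 to compound 3 (0.16 log units; within the scatter).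

Compound 4 `O=C(Nc1ccc(NCc2cnccc2Cl)cc1Cl)c1cc(Cl)ccc1O` differs from compound 1 as follows: (4-chloropyridin-3-yl)methyl in place of isopropyl on a nitrogen on an aromatic ring. This change is of the same kind as those leading to compound 2 and compound 3, an arylmethyl in place of isopropyl on the same nitrogen, so both of those steps bear on it and both were beyond the scatter and in the same direction. A step of comparable size and direction is therefore expected in this assay, that is a 5.5-fold higher number from compound 1 to compound 4 (0.74 log units; beyond the scatter). For compound 4 the estimate in this assay is 60000 nM, with a range from 20000 nM to 160000 nM.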

Compound 4, half-maximal cytotoxic concentration: 126000 nM
Compound 4: middle estimate off by 2.1-fold (0.32 log units), on the low side; measured number inside the range.
By their numbers in this assay, from the lowest: compound 1; then compounds 2, 3 and 4 (each within the scatter of the next).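

In this assay the (4-chloropyridin-3-yl)methyl group on the nitrogen also gives a large step, an 11-fold higher number from compound 1 to compound 4 (1.06 log units; beyond the scatter), so the rise seen with compounds 2 and 3 extends to an aromatic ring with a hetero atom and a chlorine. The three arylmethyl groups are not told apart here, with a 1.1-fold higher number from compound 3 to compound 4 (0.04 log units; within the scatter) and a 1.6-fold higher number from compound 2 to compound 4 (0.19 log units; within the scatter), so at this position the readable difference lies between isopropyl and the arylmethyl groups, and not among the rings. No measurement in hand gives a reason for this step.

As far as these compounds go, whether the rise belongs to the aromatic ring or simply to a larger group on the nitrogen stays open. A cyclohexylmethyl group or a longer alkyl chain at this place would separate the two.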